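Side-chain swap on a urea series: compound 3 to compound 4

The source may hold more compounds than are shown below. What is called first, only, known or untested is meant among the compounds shown, and "the series" means these compounds.

Measured in a functional assay on MCF7 cells (Homo sapiens) for cytotoxicity, read by MTT assay, with a stated time of 72 h; a higher number here means a weaker inhibitor, a lower number a stronger inhibitor:
compound 1 `COc1ncc(-c2ccc3nc(NC(=O)N(C)C)nn3c2)cc1NS(=O)(=O)c1ccc(F)cc1`: 1560 nM
compound 2 `COc1ncc(-c2ccc3nc(NC(=O)NC4CC4)nn3c2)cc1NS(=O)(=O)c1ccc(F)cc1`: 300 nM
compound 3 `COc1ncc(-c2ccc3nc(NC(=O)NCC(=O)N4CCCC4)nn3c2)cc1NS(=O)(=O)c1ccc(F)cc1`: 2130 nM

Compound 3 lies within the scatter of compound 1, with a 1.4-fold higher number from compound 1 to compound 3 (0.14 log units; within the scatter) as the measured step. Compound 2 stands apart, with a 5.2-fold lower number from compound 1 to compound 2 (0.72 log units; beyond the scatter) and a 7.1-fold higher number from compound 2 to compound 3 (0.85 log units; beyond the scatter) both beyond it. Compound 4 `COc1ncc(-c2ccc3nc(NC(=O)NCCN(C)C)nn3c2)cc1NS(=O)(=O)c1ccc(F)cc1` carries a new group: (dimethylamino)methyl in place of (pyrrolidin-1-yl)carbonyl on a saturated chain carbon bound to an amide-type nitrogen. Among the compounds with values here, no measured step makes this exact change. Within the data shown here, the steps to compound 2 show only that changes here can move the number modestly, without fixing a direction. A small fall is expected, namely a 1.5-fold lower number from compound 3 to compound 4 (0.18 log units; within the scatter) and so no clear step. Compound 4 is estimated at 1400 nM with a range of 400 nM to 4000 nM in this assay as the expected window.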

Compound 4, half-maximal inhibitory concentration: 560 nM
Estimate against measurement, compound 4: 2.5-fold (0.40 log units) above; measured number inside the range.
By their numbers in this assay, from the lowest: compounds 2 and 4 (each within the scatter of the next); then compounds 1 and 3 (each within the scatter of the next).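

In this assay, (dimethylamino)methyl in place of (pyrrolidin-1-yl)carbonyl on a saturated chain carbon bound to an amide-type nitrogen gives a 3.8-fold lower number from compound 3 to compound 4 (0.58 log units; beyond the scatter), so a longer side chain here need not stay with the higher numbers. The 2-(dimethylamino)ethyl group also gives a 2.8-fold lower number from compound 1 to compound 4 (0.44 log units; beyond the scatter), while a 1.9-fold higher number from compound 2 to compound 4 (0.27 log units; within the scatter) leaves it not clearly apart from cyclopropyl, so a ring is not required on this nitrogen. No measurement at hand explains the shift. From the compounds shown here alone, it remains open whether the dimethylamino group itself matters, or whether a pyrrolidin-1-yl group, a morpholine or a primary amine on the same ethyl chain would serve equally. A longer chain, such as 3-(dimethylamino)propyl, also remains untested in the compounds shown.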